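A few compounds are considered here, and "the series" means these few. Any claim that something is new, unique, unknown or untested is made for them only; others in the source may bear on it.

- Compound 1 `CCOC(=O)c1c(-c2cccc(Cl)c2)[nH]c2cc(OC)c(F)cc2c1=O`: 0.5 mL.min-1.g-1
- Compound 2 `CCOC(=O)c1c(-c2cccc(Br)c2)[nH]c2cc(OC)c(F)cc2c1=O`: 1.2 mL.min-1.g-1

In an in vitro ADME assay on microsomes from liver (Homo sapiens) for metabolic stability, read by HPLC, with a stated time of 4 h (a higher number here means faster removal of the compound, a lower number slower removal), compound 2 gives 1.2 mL.min-1.g-1, the higher of the two numbers. Compound 3 `CCOC(=O)c1c(-c2cc(F)cc(OC)c2)[nH]c2cc(OC)c(F)cc2c1=O` has 3-fluoro-5-methoxyphenyl in place of 3-bromophenyl on an aromatic carbon. Within the data shown here, the only measured step, a 2.4-fold higher number from compound 1 to compound 2 (0.38 log units; beyond the scatter), is modest, though beyond the scatter, and involves only bromo in place of chloro. Among the measured compounds shown here, it offers no direct precedent for this change, so no direction can be read from it, and no step beyond the scatter is expected. The estimated step is no change at the digits printed from compound 2 to compound 3 (within the scatter). For compound 3, the expected value is 1.2 mL.min-1.g-1, with an estimated range of 0.5 mL.min-1.g-1 to 3 mL.min-1.g-1.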

Compound 3, intrinsic clearance in microsomes: 56 mL.min-1.g-1
Compound 3: middle estimate off by 47-fold (1.67 log units), on the low side, and the stated range ends below it.
By their numbers in this assay, from the lowest: compound 1; then compound 2; then compound 3.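

At this position, next to the ring nitrogen, swapping the whole aryl group matters far more in this assay than exchanging one halogen for another did. 3-Fluoro-5-methoxyphenyl in place of 3-bromophenyl gives a 47-fold higher number from compound 2 to compound 3 (1.67 log units; beyond the scatter), and in place of 3-chlorophenyl it gives a 110-fold higher number from compound 1 to compound 3 (2.05 log units; beyond the scatter). Nothing available explains this rise. The compounds shown leave open whether the methoxy or the fluoro substituent accounts for the step, as 3-methoxyphenyl and 3-fluorophenyl alone would test. As far as these compounds go, how an aminophenyl or a carboxylic acid on this ring would behave also remains open.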